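Phenyl substituent change on the shared core, compound 3

The source may hold more compounds than are shown below. What is called first, only, known or untested is meant among the compounds shown, and "the series" means these compounds.

Compound 1 `COc1ccc(-c2cn(C/C=C3\OC(=O)C(OCc4ccccc4)=C3OCc3ccccc3)nn2)cc1` is examined in a functional assay on CFPAC-1 cells (Homo sapiens) for antiproliferative activity, read by MTT assay, with a stated time of 72 h; on this read-out lower numbers stand for stronger inhibition and higher numbers for weaker inhibition; compound 1 gives > 100000 nM, which is a limit of the assay and not a number, so compound 1 sits at the limit of > 100000 nM in this assay, at which 1 of the 2 values shown sits. Compound 2 `COc1ccc(-c2cn(C[C@H](O)[C@H]3OC(=O)C(OCc4ccccc4)=C3OCc3ccccc3)nn2)cc1` carries a different core and in this assay compound 2 gives 26000 nM. Compound 3 `O=C1O/C(=C\Cn2cc(-c3cccc(O)c3)nn2)C(OCc2ccccc2)=C1OCc1ccccc1` keeps the core of compound 1 and differs from it in one place: 3-hydroxyphenyl in place of 4-methoxyphenyl on an aromatic carbon. Within the data shown here, no step between measured compounds covers this change, so the size it carries is unknown from the data; the expectation is for a shift in this assay that does not go beyond the scatter, in either direction, since compound 1 is seen only at its limit. The expected step is an at least 1.2-fold lower number from compound 1 to compound 3 (0.09 log units; that floor lies within the scatter), with a fair chance that this assay again reports only a limit. Compound 3 is expected to give 80000 nM, between 25000 nM and 250000 nM.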

Compound 3, half-maximal inhibitory concentration: 33700 nM
Beside the measured number, compound 3's estimate is 2.4-fold (0.38 log units) above it; the measured number falls inside the stated range.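

On the shared core, the aromatic group on the five-membered aromatic ring with 3 nitrogen does affect the read-out: in this assay, 3-hydroxyphenyl in place of 4-methoxyphenyl gives an at least 2.9-fold lower number from compound 1 to compound 3 (0.47 log units; beyond the scatter). The change also gives a measured number where the 4-methoxyphenyl compound gave none, with compound 3 at 33700 nM. Compound 1 is known only as a limit, so this step is a floor and its full size stays unknown: the limit of > 100000 nM in this assay, at which 1 of the 3 values shown sits.

Open, on these data alone, is whether the step belongs to the hydroxy group or to its place on the phenyl ring, a question that 4-hydroxyphenyl or 3-methoxyphenyl would settle, and whether 3-aminophenyl would read the same way. Also open, as far as these compounds go, is whether the step carries over to the core of compound 2.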